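Ester side chains and cytotoxicity: compound 1 to compound 4

A few compounds are considered here, and "the series" means these few. Any claim that something is new, unique, unknown or untested is made for them only; others in the source may bear on it.

In an ADME assay on HepG2 2.2.15 cells (Homo sapiens) for cytotoxicity (on this read-out higher numbers stand for lower toxicity in this test and lower numbers for higher toxicity in this test), compound 1 (`O=c1[nH]c2ccc(Cl)cc2c(-c2ccccc2Cl)c1CCO`) gives 380000 nM. With (methoxymethyl)carbonyl in place of hydrogen on the oxygen on a saturated carbon, compound 2 (`COCC(=O)OCCc1c(-c2ccccc2Cl)c2cc(Cl)ccc2[nH]c1=O`) gives 74000 nM. With (ethoxymethyl)carbonyl at that place, compound 3 (`CCOCC(=O)OCCc1c(-c2ccccc2Cl)c2cc(Cl)ccc2[nH]c1=O`) gives 130000 nM.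

Compound 3 therefore stands apart from the parent, with a 2.9-fold lower number from compound 1 to compound 3 (0.47 log units; beyond the scatter), a modest step beyond the scatter. It cannot be separated from its nearest neighbour, with a 1.8-fold higher number from compound 2 to compound 3 (0.24 log units; within the scatter), which lies within the scatter.

The next structure is compound 4 (`CC(=O)NCC(=O)OCCc1c(-c2ccccc2Cl)c2cc(Cl)ccc2[nH]c1=O`). The change is acetamido in place of ethoxy on a saturated chain carbon bound to a carbonyl carbon. Going by the values given here, no measured step covers this exchange directly. The closest guide is the change at the same end of the chain, which gave a 1.8-fold higher number from compound 2 to compound 3 (0.24 log units; within the scatter). The larger step on acylation, a 5.1-fold lower number from compound 1 to compound 2 (0.71 log units; beyond the scatter), is not repeated here, since compound 3 already carries a carbonyl at that place.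

No step beyond the scatter is therefore expected in this assay, and the estimated step is a 1.2-fold higher number from compound 3 to compound 4 (0.06 log units; within the scatter). The expected value for compound 4 is 150000 nM, with an estimated range from 65000 nM to 350000 nM.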

Compound 4, half-maximal cytotoxic concentration: 110000 nM
Compound 4: middle estimate off by 1.4-fold (0.13 log units), on the high side, and the stated range covers the measured number.
By their numbers in this assay, from the lowest: compounds 2, 4 and 3 (each within the scatter of the next); then compound 1.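

In this assay, acetamido in place of ethoxy on a saturated chain carbon bound to a carbonyl carbon brings a nitrogen and a hydrogen-bond donor into the side chain without a step beyond the scatter (a 1.2-fold lower number from compound 3 to compound 4 (0.07 log units; within the scatter)), and the same holds for acetamido in place of methoxy at that place (a 1.5-fold higher number from compound 2 to compound 4 (0.17 log units; within the scatter)). Compound 4 thus joins compound 2 and compound 3 as a group of esters that cannot be separated from one another, so the identity of this terminal group has shown no effect beyond the scatter across ethoxy, methoxy and acetamido. The separation from the parent alcohol also persists with the nitrogen-bearing side chain (a 3.5-fold lower number from compound 1 to compound 4 (0.54 log units; beyond the scatter)), a modest step beyond the scatter, and nothing available here bears on the reason for this behaviour.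

Open, as far as these compounds go, is whether a primary amine, a carboxylic acid or a longer chain at this place would stay with these three esters or move toward compound 1. Also open, from the compounds shown here alone, is whether these side chains remain inseparable in any read-out other than this assay.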